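Adding a Fourth Methyl to the Core of Compound 3

The source may report more compounds than this note shows. Statements on the series, on what has been measured and on what is new or still open speak of the compounds shown alone.

Measured compounds:
Compound 1, `CCCCc1cc(OC)c2c(C)cc(C)c(C)c2c1OC(C)=O`, gives 11900 nM
Compound 2, `CCCCc1cc(OC)c2c(C)ccc(C)c2c1OC(C)=O`, gives 7350 nM
Compound 3, `CCc1c(CC)c(OC(C)=O)c2c(C)c(C)cc(C)c2c1OC`, gives 15700 nM

All three were tested in a functional assay for inhibition, with Rattus norvegicus as the target; on this read-out lower numbers stand for stronger inhibition and higher numbers for weaker inhibition. Compound 2 and compound 1 differ in one place, (methyl in place of hydrogen on an aromatic carbon). That step is a 1.6-fold higher number from compound 2 to compound 1 (0.21 log units; within the scatter). Compound 3 has a different core from compound 2, and the difference between the two cores is not broken down here; compound 3 stands as the highest of the three numbers, though its gap to compound 1 lies within the scatter.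

Compound 4, `CCc1c(CC)c(OC(C)=O)c2c(C)c(C)c(C)c(C)c2c1OC`, has not yet been measured. It differs from compound 3 by methyl in place of hydrogen on an aromatic carbon. This is the same kind of change as that from compound 2 to compound 1, not the same: in compound 4 the new methyl is ortho to two methyl groups, whereas in compound 1 it is ortho to a methyl group.

For compound 4 the expected step is a 1.4-fold higher number from compound 3 to compound 4 (0.15 log units; within the scatter). This expectation rests on the earlier step of a 1.6-fold higher number from compound 2 to compound 1 (0.21 log units; within the scatter), a small shift within the scatter. Compound 4 is therefore estimated at 22000 nM, expected to lie between 10000 nM and 50000 nM.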

Compound 4, half-maximal inhibitory concentration: 37300 nM
Beside the measured number, compound 4's estimate is 1.7-fold (0.23 log units) below it; the range from low to high includes it.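

In this assay, methyl in place of hydrogen on an aromatic carbon gives a 2.4-fold higher number from compound 3 to compound 4 (0.38 log units; beyond the scatter). Set beside the same change on the other core, the two steps cannot be told apart: the same change on two cores in this assay, a 1.6-fold higher number (0.21 log units; within the scatter) from compound 2 to compound 1 and a 2.4-fold higher number (0.38 log units; beyond the scatter) from compound 3 to compound 4, 1.5-fold (0.17 log units) apart, within the scatter of two such steps. For the compounds shown here, the two cores therefore give no sign that this change behaves differently from one to the other, though only the step to compound 4 clears the scatter by itself, and two pairs cannot show that the same would hold on a further core or tell whether the new methyl's surroundings matter.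

Every change shown here is a single methyl on the aromatic ring, so the compounds leave open what a chlorine atom, an amine or a longer chain such as propyl would do at that place. From the compounds shown here alone, it also remains open whether the step would look the same with a free hydroxyl group in place of the acetate ester.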